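Methylsulfonyl on the ring nitrogen of compound 2

The source may hold more compounds than are shown below. What is called first, only, known or untested is meant among the compounds shown, and "the series" means these compounds.

The measured compounds are:
compound 1 `CN(C)c1ccc(C2CC(c3ccc(-n4cncn4)cc3)=NN2)cc1` with -3.3%;
compound 2 `CN(C)c1ccc(C2CC(c3ccc(-n4ccnc4)cc3)=NN2)cc1` with 0.1%;
compound 3 `CN(C)c1ccc(C2CC(c3ccc(-n4cncn4)cc3)=NN2S(=O)(=O)c2ccc(F)cc2)cc1` with -0.5%.

In a functional assay on NCI-H1975 cells (Homo sapiens) for inhibition, read by sulforhodamine B assay, tested at 10 uM (a higher number here means more inhibition at the concentration tested (going by the name of the read-out), a lower number less inhibition), compound 2 gives 0.1%, and the numbers of compound 1 and compound 3 both lie within the scatter of it; nothing separates the three, and none of them shows inhibition at the concentration tested. Compound 4 `CN(C)c1ccc(C2CC(c3ccc(-n4ccnc4)cc3)=NN2S(C)(=O)=O)cc1` differs from compound 2 in one place: methylsulfonyl in place of hydrogen on an amine nitrogen in a ring. The step that bears on this change is the one on the same ring nitrogen, a number 2.8 percentage points higher from compound 1 to compound 3 (within the scatter), which is within the scatter; the change of the aromatic ring, a number 3.4 percentage points higher from compound 1 to compound 2 (within the scatter), is also within the scatter. Among the compounds with values here, a sulfonyl group on that ring nitrogen therefore left the read-out unchanged once, and no step in this set moved beyond the scatter. The expected step from compound 2 to compound 4 in this assay is a number 0.9 percentage points higher from compound 2 to compound 4 (within the scatter), which is none beyond the scatter. Compound 4 is thus estimated at 1%, within the range -10% to 12%.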

Compound 4, a percentage reported as inhibition, at one concentration (the size of the read-out at that concentration, not a potency): -3.8%
Compound 4: middle estimate off by 4.8 percentage points, on the high side; measured number inside the range.
By their numbers in this assay, from the lowest: compounds 4, 1, 3 and 2 (each within the scatter of the next).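

In this assay, putting methylsulfonyl in place of hydrogen on the amine nitrogen in the ring gives a number 3.9 percentage points lower from compound 2 to compound 4 (within the scatter). Within the data shown here, until now, the only sulfonyl step on this nitrogen was the (4-fluorophenyl)sulfonyl one on the 1H-1,2,4-triazol-1-yl compound, a number 2.8 percentage points higher from compound 1 to compound 3 (within the scatter); the new step shows the same outcome with a methylsulfonyl group and with 1H-imidazol-1-yl on the aromatic carbon, so neither sulfonyl group separates its compound from its parent in this assay. Nothing available bears on why this position stays silent.

All four compounds remain within the scatter of one another, so the set cannot show whether this nitrogen matters in a compound that does inhibit these cells. From the compounds shown here alone, whether an acetyl group or a longer chain on that nitrogen, or a carboxylic acid in place of the dimethylamino group, would move the read-out beyond the scatter stays open.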